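A methoxyphenyl to methoxypyridinyl swap, one result open

The source may hold more compounds than are shown below. What is called first, only, known or untested is meant among the compounds shown, and "the series" means these compounds.

Measured in an ADME assay on microsomes from liver (Rattus norvegicus), read by LC-MS, using NADPH, with a stated time of 10 min, tested at 0.5 uM; on this read-out lower numbers stand for a less stable compound and higher numbers for a more stable compound:
- compound 1 `Cc1nc2cc(-c3cccc(OCc4ccccc4)c3)nn2c(-c2cc(F)c3c(c2C)CCCO3)c1C(OC(C)(C)C)C(=O)O` gives 83%
- compound 2 `Cc1nc2cc(-c3cccc(-c4ccccc4)c3)nn2c(-c2cc(F)c3c(c2C)CCCO3)c1C(OC(C)(C)C)C(=O)O` gives 100%
- compound 3 `COc1ccccc1-c1cccc(-c2cc3nc(C)c([C@H](OC(C)(C)C)C(=O)O)c(-c4cc(F)c5c(c4C)CCCO5)n3n2)c1` gives 99%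

Compound 3 stands near the top of this small set. In this assay compound 3 gives 99%, within the scatter of compound 2 at 100% and well clear of compound 1 at 83%.

The open case is compound 4 `COc1ccc(-c2cccc(-c3cc4nc(C)c([C@H](OC(C)(C)C)C(=O)O)c(-c5cc(F)c6c(c5C)CCCO6)n4n3)c2)cn1`, which alters a single group of compound 3: 6-methoxypyridin-3-yl in place of 2-methoxyphenyl on an aromatic carbon. Here 6-methoxypyridin-3-yl takes the place of 2-methoxyphenyl on an aromatic carbon, meta to a large group. Within the data shown here, only one measured step bears on this place, a number 17 percentage points higher from compound 1 to compound 2 (beyond the scatter), and it is modest and exchanges a different pair of groups. Among the measured compounds shown here, no measured compound yet carries a ring nitrogen here.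

With so little guidance, only a small fall or no real change is expected, and the estimated step is a number 6 percentage points lower from compound 3 to compound 4 (within the scatter), not expected to pass the scatter. The estimate for compound 4 is 93%, expected to lie between 80% and 100%.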

Compound 4, percent of the compound remaining: 100%
Compound 4: middle estimate off by 7 percentage points, on the low side, within the range that was stated.
By their numbers in this assay, from the lowest: compound 1; then compounds 3, 2 and 4 (each within the scatter of the next).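

In this assay, 6-methoxypyridin-3-yl in place of 2-methoxyphenyl gives a number 1 percentage points higher from compound 3 to compound 4 (within the scatter). Compound 4 is the first compound shown with a ring nitrogen at this place, and this exchange of a carbon-only ring for a ring with one hetero atom, which adds a hydrogen-bond acceptor to the count, leaves the percent remaining without any real change. Nothing measured here gives a reason for that outcome.

The two names differ in more than the ring nitrogen, so this one step cannot separate the share of the nitrogen from that of the other difference between the two groups. From the compounds shown here alone, it also remains open whether the percent remaining would hold with an amine, a carboxylic acid or a longer chain in place of the methoxy group.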